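Swapping 3,4-difluorophenyl for cycloheptyl: cytotoxicity notes

This account rests on a few compounds, and the source may have more. Where it says the series, first, only, none or still open, it means among the compounds named here.

Compound 1 `COc1ccc(C2(c3cccc(O)c3)C(=O)Nc3c2ccc(F)c3F)cc1`: 196 nM
Compound 2 `O=C1Nc2c(ccc(F)c2F)C1(c1ccc(O)cc1)c1ccc(F)c(F)c1`: 7.8 nM

In a functional assay on MCF7 cells (Homo sapiens) for cytotoxicity, read by WST assay, with a stated time of 72 h (a lower number here means a stronger inhibitor, a higher number a weaker inhibitor), compound 2 has the lower of the two numbers, and its gap to compound 1 lies beyond the scatter. Compound 3 `O=C1Nc2c(ccc(F)c2F)C1(c1ccc(O)cc1)C1CCCCCC1` carries cycloheptyl in place of 3,4-difluorophenyl on a saturated ring carbon. Going by the values given here, no measured pair of compounds differing in one place is available, so this expectation has no direct precedent. The expected change is moderate, toward a weaker inhibitor and slightly beyond the scatter: a 2.6-fold higher number from compound 2 to compound 3 (0.41 log units; beyond the scatter). The estimated value for compound 3 is 20 nM, with an expected range of 4 nM to 120 nM.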

Compound 3, half-maximal inhibitory concentration: 1.2 nM
Compound 3: the middle estimate sits 17-fold (1.22 log units) above what was measured, outside the stated range (below it).
By their numbers in this assay, from the lowest: compound 3; then compound 2; then compound 1.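

Replacing 3,4-difluorophenyl with cycloheptyl on a saturated ring carbon gives a 6.5-fold lower number from compound 2 to compound 3 (0.81 log units; beyond the scatter) in this assay. In this pair, an aromatic ring at this position is therefore not needed for a low number, and a seven-membered non-aromatic carbon ring is tolerated. Nothing at hand accounts for the step.

From the compounds shown here alone, whether the step follows ring size or the loss of the aromatic ring remains open. Cyclohexyl or an open heptyl chain on the same carbon would help separate the two.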